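Swapping an aromatic ring for hydroxymethyl on the amide carbonyl

The source may hold more compounds than are shown below. What is called first, only, known or untested is meant among the compounds shown, and "the series" means these compounds.

Of the compounds shown here, two have been measured in an assay on isolated protein for displacement of a labelled ligand from 5-hydroxytryptamine receptor 6 (Homo sapiens); on this read-out higher numbers stand for weaker inhibition and lower numbers for stronger inhibition. Compound 1 `CN(C)CC1CCCc2cc(S(=O)(=O)c3ccccc3)ccc21` gives 0.0631 nM, the lower of the two numbers. Compound 2 `O=C(NC[C@@H]1CCCc2cc(S(=O)(=O)c3cccc(F)c3)ccc21)c1ccc[nH]1` gives 5.01 nM in this assay, the higher of the two numbers, and its gap to compound 1 lies well beyond the usual scatter. Compound 2 therefore stands as the weaker binder of the pair.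

Compound 3 `O=C(CO)NC[C@@H]1CCCc2cc(S(=O)(=O)c3cccc(F)c3)ccc21` has not yet been measured. It keeps the core of compound 2 and differs only at the carbonyl carbon that sits on the amide-type nitrogen: hydroxymethyl in place of 1H-pyrrol-2-yl on a carbonyl carbon.

Among the compounds with values here, no measured pair shows this exact change, so the direction rests on judgement rather than on a recorded step. The expectation is a rise in the number, that is weaker binding, with the step of a 6.0-fold higher number from compound 2 to compound 3 (0.78 log units; beyond the scatter) expected to exceed the scatter. Compound 3 is thus estimated at 30 nM in this assay, with a plausible range from 5 nM to 200 nM.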

Compound 3, inhibition constant: 0.1 nM
Compound 3: middle estimate off by 300-fold (2.48 log units), on the high side; measured number below the stated range.
By their numbers in this assay, from the lowest: compounds 1 and 3 (each within the scatter of the next); then compound 2.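

In this assay the group on this carbonyl carbon has a strong influence on binding: hydroxymethyl in place of 1H-pyrrol-2-yl gives a 50-fold lower number from compound 2 to compound 3 (1.70 log units; beyond the scatter) and so much stronger binding. At this place, then, the five-membered aromatic ring is not needed for strong binding, and the smaller hydroxymethyl, with no ring, does far better in this pair. Nothing measured here gives a reason for a step of this size.

On these data alone, what stays open is whether the gain comes from the hydroxyl oxygen or simply from losing the ring, and a plain methyl or an aminomethyl on the same carbonyl carbon would help to separate the two. How far this place tolerates growth is also unknown, and a longer chain such as 2-hydroxyethyl would test that.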